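A few compounds are considered here, and "the series" means these few. Any claim that something is new, unique, unknown or untested is made for them only; others in the source may bear on it.

The series shares one core, carried here by compound 1 `COc1cc(/C=C/c2ccc(NC(=O)/C=C/c3ccc(OC)c(OC)c3)cc2)cc(OC)c1`, compound 2 `COc1cc(/C=C/c2ccc(NC(=O)/C=C/c3cccc(F)c3)cc2)cc(OC)c1` and compound 3 `COc1cc(/C=C/c2ccc(NC(=O)/C=C/c3ccc(F)cc3F)cc2)cc(OC)c1`. In a functional assay on HT-29 cells (Homo sapiens) for inhibition, read by MTT assay, with a stated time of 48 h (a higher number here means a weaker inhibitor, a lower number a stronger inhibitor), compound 1 gives 960 nM. In this assay compound 2 gives 16800 nM, and compound 3 gives 18100 nM in this assay. Compound 3 thus stands highest of the three numbers, though one of its gaps is within the scatter, a 1.1-fold higher number from compound 2 to compound 3 (0.03 log units; within the scatter), and only the other is large, a 19-fold higher number from compound 1 to compound 3 (1.28 log units; beyond the scatter).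

Compound 4 `COc1cc(/C=C/c2ccc(NC(=O)/C=C/c3ccc(Cl)cc3)cc2)cc(OC)c1` is not yet measured. It differs from compound 3 by 4-chlorophenyl in place of 2,4-difluorophenyl on a double-bonded chain carbon bound to a double-bonded chain carbon. Within the data shown here, two steps bear on this change: the move from a dimethoxy-bearing ring to a fluorine-bearing ring was large, an 18-fold higher number from compound 1 to compound 2 (1.24 log units; beyond the scatter) and a 19-fold higher number from compound 1 to compound 3 (1.28 log units; beyond the scatter), while changing the pattern of fluorines gave only a 1.1-fold higher number from compound 2 to compound 3 (0.03 log units; within the scatter). Among the measured compounds shown here, no measured compound carries chlorine, so the step is expected to be small, a 1.2-fold lower number from compound 3 to compound 4 (0.08 log units; within the scatter), in this assay. Compound 4 is therefore estimated at 15000 nM, with a range from 6000 nM to 40000 nM.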

Compound 4, half-maximal inhibitory concentration: 10300 nM
Compound 4: middle estimate off by 1.5-fold (0.16 log units), on the high side, within the range that was stated.
By their numbers in this assay, from the lowest: compound 1; then compounds 4, 2 and 3 (each within the scatter of the next).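

At this place, on a double-bonded chain carbon bound to a double-bonded chain carbon, 4-chlorophenyl and 2,4-difluorophenyl do not separate in this assay (a 1.8-fold lower number from compound 3 to compound 4 (0.24 log units; within the scatter)), nor do 4-chlorophenyl and 3-fluorophenyl (a 1.6-fold lower number from compound 2 to compound 4 (0.21 log units; within the scatter)). A chlorine-bearing ring therefore stands with the two fluorine-bearing rings, and the large gap from 3,4-dimethoxyphenyl now holds for a third ring that carries a halogen (an 11-fold higher number from compound 1 to compound 4 (1.03 log units; beyond the scatter)). Nothing available explains either the closeness of these three rings or their distance from compound 1.

The compounds shown leave open whether a ring with a single methoxy group, a hydroxyl or an amine would stand with compound 1 or with the halogen-bearing rings. They also leave open whether bromine in the place of chlorine would keep compound 4's standing.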